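Halogen swap on the anilino ring of the shared core

The compounds below may be only part of what the source reports. "The series", "measured", "known", "first", "only" and "open" are said of these compounds alone.

Of the compounds shown here, two have numbers so far. Compound 1 `COc1cccc(NC(=O)CSc2nc(Nc3ccccc3)c3ccccc3n2)c1` carries a 3-methoxyphenyl amide; in a functional assay on PC-3 cells (Homo sapiens) for inhibition, read by MTT assay, with a stated time of 72 h (on this read-out higher numbers stand for weaker inhibition and lower numbers for stronger inhibition), compound 1 gives 11600 nM. Compound 2 `C=CC(=O)Nc1cccc(NC(=O)CSc2nc(Nc3cccc(Cl)c3)c3ccccc3n2)c1` carries an acrylamide on that ring and a 3-chlorophenyl on the aromatic nitrogen; in this assay compound 2 gives 12300 nM. The two values lie within the scatter of each other, so the numbers shown separate nothing between them.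

Compound 3 `C=CC(=O)Nc1cccc(NC(=O)CSc2nc(Nc3ccc(Br)cc3)c3ccccc3n2)c1` keeps everything of compound 2 except one change: 4-bromophenyl in place of 3-chlorophenyl on a nitrogen on an aromatic ring. For the measured compounds named here, no measured pair shows what such a halogen move does, so the direction is open. Given the flat picture so far, the step from compound 2 to compound 3 in this assay is expected to be small, a 1.0-fold lower number from compound 2 to compound 3 (0.01 log units; within the scatter), not beyond the scatter. For compound 3 in this assay the estimate is 12000 nM, with a range from 5000 nM to 30000 nM.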

Compound 3, half-maximal inhibitory concentration: 12400 nM
Estimate against measurement, compound 3: 1.0-fold (0.01 log units) below; low and high end bracket the measured number.
By their numbers in this assay, from the lowest: compounds 1, 2 and 3 (each within the scatter of the next).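

In this assay, for the compounds shown here, the first single-place step reads a 1.0-fold higher number from compound 2 to compound 3 (0.00 log units; within the scatter), so 4-bromophenyl in place of 3-chlorophenyl on a nitrogen on an aromatic ring separates nothing at this position. A change of both the halogen and its place on the phenyl ring is thus tolerated here without a shift beyond the scatter. Nothing on hand offers an explanation for this flat step.

Going by these compounds alone, this single pair cannot tell the halogen change from the change in its place on the ring, and compound 1 and compound 2 differ in more than one place, so no step between them can be read. Also open, as far as these compounds go, is whether an amine or a carboxylic acid on this phenyl ring, or a longer chain in its stead, would move the number beyond the scatter.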